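From a branched chain to a ring at the carbonyl

The source may hold more compounds than are shown below. What is called first, only, known or untested is meant among the compounds shown, and "the series" means these compounds.

compound 1 `CC(C)=CC[C@@H](OC[C@@H](C)O)C1=CC(=O)c2c(O)ccc(O)c2C1=O` gives 22500 nM
compound 2 `CC(C)=CC[C@@H](OCC(C)O)C1=CC(=O)c2c(O)ccc(O)c2C1=O` gives 24700 nM
compound 3 `CC(C)=CC[C@@H](OC(=O)CC(C)(O)C(C)C)C1=CC(=O)c2c(O)ccc(O)c2C1=O` gives 27700 nM

All three values come from a functional assay on HeLa cells (Homo sapiens) for cytotoxicity, read by MTT assay (a higher number here means a weaker inhibitor, a lower number a stronger inhibitor), and they sit close together. Compound 3 stands level with the other two, since a 1.2-fold higher number from compound 1 to compound 3 (0.09 log units; within the scatter) and a 1.1-fold higher number from compound 2 to compound 3 (0.05 log units; within the scatter) do not separate it from either.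

Compound 4 `CC(C)=CC[C@@H](OC(=O)C1CCCO1)C1=CC(=O)c2c(O)ccc(O)c2C1=O` has not been measured yet. It differs from compound 3 in one place, on a carbonyl carbon, where oxolan-2-yl stands in place of 2-hydroxy-2,3-dimethylbutyl: oxolan-2-yl in place of 2-hydroxy-2,3-dimethylbutyl on a carbonyl carbon is the whole of the change.

Within the data shown here, no measured compound carries oxolan-2-yl, so the nearest guide is the change that produced compound 3. Putting (2-hydroxy-2,3-dimethylbutyl)carbonyl in place of 2-hydroxypropyl gave the two small steps above, a 1.2-fold higher number from compound 1 to compound 3 (0.09 log units; within the scatter) and a 1.1-fold higher number from compound 2 to compound 3 (0.05 log units; within the scatter) again. The remaining step, a 1.1-fold higher number from compound 1 to compound 2 (0.04 log units; within the scatter), goes with the fact that one of compounds 1 and 2 is drawn with a defined configuration and the other without, at the place where they differ and is just as small. On that basis, no step beyond the scatter is expected in this assay for this swap, and no firm direction either.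

The estimated step is a 1.2-fold lower number from compound 3 to compound 4 (0.06 log units; within the scatter) and it would leave the two compounds level.

Compound 4 is expected to come in at 24000 nM with a range of 11000 nM to 50000 nM for four in five measurements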

Compound 4, half-maximal inhibitory concentration: 17000 nM
Estimate against measurement, compound 4: 1.4-fold (0.15 log units) above, within the range that was stated.
By their numbers in this assay, from the lowest: compounds 4, 1, 2 and 3 (each within the scatter of the next).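

In this assay, setting the ring oxolan-2-yl on the carbonyl carbon in place of the open chain 2-hydroxy-2,3-dimethylbutyl gives a 1.6-fold lower number from compound 3 to compound 4 (0.21 log units; within the scatter), so this place accepts a five-membered non-aromatic ring as well as a branched chain. The comparisons with the two compounds that carry 2-hydroxypropyl on the oxygen agree, with a 1.5-fold lower number from compound 2 to compound 4 (0.16 log units; within the scatter) and a 1.3-fold lower number from compound 1 to compound 4 (0.12 log units; within the scatter), and none of the three steps separates compound 4 from the others. The earlier compounds shown here all carried a hydroxyl group on the side chain, whereas the oxolan-2-yl group of compound 4 has no hydrogen-bond donor, and this change still leaves the number within the scatter, so that donor is not needed to keep this level of cytotoxicity in these cells.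

From the compounds shown here alone, whether an amine, a carboxylic acid or a longer chain on this carbonyl carbon would move the number beyond the scatter stays open, since all four compounds sit level. Nothing available here bears on why the oxolan-2-yl compound falls where it does.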